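The compounds below may be only part of what the source reports. "The series", "measured", "known", "first", "only" and "open" are said of these compounds alone.

In a functional assay on OVCAR-3 cells (Homo sapiens) for antiproliferative activity, read by WST assay, with a stated time of 72 h (on this read-out higher numbers stand for weaker inhibition of growth and lower numbers for stronger inhibition of growth), compound 1 `C#Cc1cccc(N/N=N/c2ccc(C(=N)N)cc2)c1` gives 16800 nM, compound 2 `N=C(N)c1ccc(/N=N/Nc2cccc(C#Cc3ccccn3)c2)cc1` gives 10700 nM and compound 3 `N=C(N)c1ccc(/N=N/Nc2ccccc2C#Cc2ccccc2)cc1` gives 8100 nM. Compound 2 stands within the scatter of both other compounds, so its place among the three numbers carries no real order. Compound 4 `COc1ccc(C#Cc2cccc(N/N=N/c3ccc(C(=N)N)cc3)c2)cc1` differs from it as follows: 4-methoxyphenyl in place of pyridin-2-yl on a triple-bonded carbon. In words, this is 4-methoxyphenyl in place of pyridin-2-yl on a triple-bonded carbon. Within the data shown here, no measured step covers this exchange. The closest is a 1.6-fold lower number from compound 1 to compound 2 (0.20 log units; within the scatter), with pyridin-2-yl in place of hydrogen on a triple-bonded carbon, and it stays within the scatter. No shift beyond the scatter is therefore expected in this assay, and no direction is favoured. The expected step is a 1.2-fold lower number from compound 2 to compound 4 (0.08 log units; within the scatter). For compound 4 the estimate is 9000 nM, with an expected range of 3500 nM to 20000 nM.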

Compound 4, concentration for 50% growth inhibition: 5200 nM
Estimate against measurement, compound 4: 1.7-fold (0.24 log units) above, and the stated range covers the measured number.
By their numbers in this assay, from the lowest: compounds 4, 3, 2 and 1 (each within the scatter of the next, the first and the last beyond it).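

In this assay the triple-bonded carbon now gives steps beyond the scatter: 4-methoxyphenyl in place of pyridin-2-yl gives a 2.1-fold lower number from compound 2 to compound 4 (0.31 log units; beyond the scatter) and 4-methoxyphenyl in place of hydrogen gives a 3.2-fold lower number from compound 1 to compound 4 (0.51 log units; beyond the scatter) and both remain modest. The number thus responds to the group at this position, which the step from hydrogen to pyridin-2-yl, within the scatter, did not show. No available evidence accounts for the difference between the two rings. 

From the compounds shown here alone, whether the methoxy group or the carbon-only ring carries the step remains open. So does the effect of an amine or a carboxylic acid on the ring at this position.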